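A Branched Chain Gives Way to a Methoxyphenyl Group

A few compounds are considered here, and "the series" means these few. Any claim that something is new, unique, unknown or untested is made for them only; others in the source may bear on it.

For the measured compounds named here, compound 2 `CCC(C)(CC)Cc1cnc(CCc2ccc(-c3ccccc3C(=O)O)cc2)[nH]1` gives 76 nM in an in vitro functional assay on cells for agonist activity at Bombesin receptor subtype-3 (Homo sapiens), read by luminescence and calcium flux (on this read-out higher numbers stand for an effect only at larger amounts of compound and lower numbers for an effect already at smaller amounts), the lowest of the two numbers so far, while compound 1 `CC(C)(C)Cc1cnc(CCc2ccc(-c3ccccc3C(=O)O)cc2)[nH]1` gives 106 nM; the step of a 1.4-fold lower number from compound 1 to compound 2 (0.14 log units; within the scatter) lies within the scatter. Compound 3 `COc1ccccc1Cc1cnc(CCc2ccc(-c3ccccc3C(=O)O)cc2)[nH]1` carries 2-methoxyphenyl in place of 1-ethyl-1-methylpropyl on a saturated chain carbon bound to an aromatic carbon. Going by the values given here, the only measured step exchanged one branched chain for another at this place, and no measured step puts an aromatic ring there, so no step bears directly on this change. Compound 3 is therefore expected, with a wide range, to give 150 nM, between 30 nM and 800 nM. The estimated step is a 2.0-fold higher number from compound 2 to compound 3 (0.30 log units; within the scatter).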

Compound 3, half-maximal effective concentration: 1720 nM
The estimate for compound 3 lay 11-fold (1.06 log units) below the measured number; the measured number lies above the stated range.
By their numbers in this assay, from the lowest: compounds 2 and 1 (each within the scatter of the next); then compound 3.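

At this place the two branched chains read alike, but an aromatic ring does not fit that picture: 2-methoxyphenyl in place of 1-ethyl-1-methylpropyl gives a large step (a 23-fold higher number from compound 2 to compound 3 (1.35 log units; beyond the scatter)), and in place of tert-butyl a similar one (a 16-fold higher number from compound 1 to compound 3 (1.21 log units; beyond the scatter)). So this position does not accept every group, and much more compound is needed for the same effect once 2-methoxyphenyl sits there. Nothing available explains this rise. Going by these compounds, whether the ring or its methoxy group goes with the loss stays open, as does how a plain phenyl or a cyclohexyl ring would read here.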